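Shifting One Fluorine Around the Ring of Compound 2

The source may hold more compounds than are shown below. What is called first, only, known or untested is meant among the compounds shown, and "the series" means these compounds.

The measured compounds, all in an assay on isolated protein for inhibition of Amine oxidase [flavin-containing] B (Homo sapiens); on this read-out higher numbers stand for weaker inhibition and lower numbers for stronger inhibition:
Compound 1, `CCOc1ccc(C(=O)/C=C/c2ccc(Br)cc2)cc1`: compound 1 gives 210 nM.
Compound 2, `O=C(/C=C/c1cccc(F)c1)c1ccc(-n2ccnc2)cc1`: compound 2 gives only a limit, > 10000 nM.
Compound 3, `CC/C(C)=N/Oc1ccc(/C=C/C(=O)c2ccc(F)cc2)cc1`: compound 3 gives 28 nM.

Compound 2 thus stands at the limit of > 10000 nM in this assay, at which 1 of the 3 values shown sits; nothing more than that limit is known of it, so its distance from compound 1 and compound 3 cannot be given as a number, only that those two return measured values while compound 2 does not.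

Compound 4, `O=C(/C=C/c1ccc(F)cc1)c1ccc(-n2ccnc2)cc1`, has not yet been measured in this assay. It differs from compound 2 in one place: 4-fluorophenyl in place of 3-fluorophenyl on a double-bonded chain carbon bound to a double-bonded chain carbon. Within the data shown here, no measured pair in this set shows what such a move of the fluorine does on this ring, so no step size can be drawn from the data. The expectation written here is that compound 4 stays near compound 2, with the step of a number no higher from compound 2 to compound 4 (the limit leaves the size open) estimated as none beyond the usual scatter, and with a fair chance that only a limit is reported again. Compound 4 is estimated at 10000 nM, expected to lie between 2000 nM and 50000 nM.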

Compound 4, half-maximal inhibitory concentration: > 10000 nM
Compound 4 was reported as a limit (the forecaster's own chance of this, stated with the estimate: 60%); the middle value sits exactly at the limit.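

Compound 2 and compound 4 are each reported only as a limit in this assay, so no step can be read between them: the limit of > 10000 nM in this assay, at which 2 of the 4 values shown sit. The compounds shown leave open what moving the fluorine from 3-fluorophenyl to 4-fluorophenyl does to inhibition, since neither compound has a measured number.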